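This account rests on a few compounds, and the source may have more. Where it says the series, first, only, none or still open, it means among the compounds named here.

Compound 3 `COc1cccc(/C=C/C(=O)c2sc(Nc3ccc(C)cc3)nc2C)c1` was examined in a functional assay on BGC-823 cells (Homo sapiens) for cytotoxicity, read by MTT assay; on this read-out lower numbers stand for stronger inhibition and higher numbers for weaker inhibition. For compound 3 the result is a limit of the assay rather than a number, > 25000 nM. Its nearest measured neighbour is compound 1 `Cc1ccc(Nc2nc(C)c(C(=O)/C=C/c3ccc(Cl)cc3)s2)cc1`; in this assay compound 1 likewise reaches only a limit, > 25000 nM. Compound 2 `Cc1ccccc1Nc1nc(C)c(C(=O)/C=C/c2ccccc2)s1` belongs to the same series; for compound 2 this assay again gives only a limit, > 25000 nM. Among the compounds with values here, the one step between measured compounds that differ in a single place, a step that the two limits leave unreadable from compound 1 to compound 3, cannot be read because of the limit of > 25000 nM in this assay, at which 3 of the 3 values shown sit. Compound 3 thus stands at the assay limit together with the other two measured compounds, and no readable number exists among the three.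

Compound 4 `Cc1ccc(Nc2nc(C)c(C(=O)/C=C/c3ccccc3)s2)cc1` differs from compound 3 by hydrogen in place of methoxy on an aromatic carbon. Within the data shown here, no measured step offers a readable size for a change on this ring; every step here is bounded by limits and yields nothing beyond the scatter that can be named. The expectation for compound 4 is that this assay again returns a limit rather than a number, so the estimated step that the limit leaves unreadable from compound 3 to compound 4 is expected to be none beyond the scatter. Compound 4 is estimated at 40000 nM, within a range from 15000 nM to 120000 nM.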

Compound 4, half-maximal inhibitory concentration: > 25000 nM
Compound 4 gave a limit, no number; the forecaster's own chance of this, stated with the estimate: 85%; the middle value lies beyond the limit too.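

In this assay, compound 4 also reaches only a limit, so none of the new steps from compound 1, compound 2 or compound 3 to compound 4 can be read, because all four compounds share that limit: the limit of > 25000 nM in this assay, at which 4 of the 4 values shown sit. The compounds shown leave open how large any of these changes is, and whether any substitution on the shared core would give a readable number.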